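Methyl additions on a branched polyene ester series

The source may report more compounds than this note shows. Statements on the series, on what has been measured and on what is new or still open speak of the compounds shown alone.

Compound 1 `CC(/C=C/CC(C)CCCC(C)C)=C\C(=O)OC(C)C` gives 7.15 in a physicochemical assay for lipophilicity; a higher number here means a more lipophilic compound, a lower number a more polar compound. Compound 2 `CC(/C=C/CC(C)CCCC(C)(C)C)=C\C(=O)OC(C)C` is its tert-butyl counterpart, and in this assay compound 2 gives 7.56. The change between them, (methyl in place of hydrogen on a saturated chain carbon bound to three saturated chain carbons), produces a number 0.41 log units higher from compound 1 to compound 2 (beyond the scatter); the same difference, cut one bond further out, reads isopropyl to tert-butyl.

Compound 3 `COC(C)(C)CCCC(C)C/C=C/C(C)=C/C(=O)SC` belongs to a second core carrying a (methylsulfanyl)carbonyl and a methoxy group; in this assay compound 3 gives 6.24, the lowest of the three numbers and beyond the scatter from both compound 1 and compound 2. The difference between the two cores is not broken down here.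

Compound 4 `CCSC(=O)/C=C(C)/C=C/CC(C)CCCC(C)(C)OC` is not yet measured. It differs from compound 3 by methyl in place of hydrogen on a saturated chain carbon bound to a sulfur, which one bond further out reads methylsulfanyl to ethylsulfanyl. This is the same kind of change as that from compound 1 to compound 2, not the same: there the place was a saturated chain carbon bound to three saturated chain carbons, here it is a saturated chain carbon bound to a sulfur.

For compound 4 the expected step in this assay is a number 0.41 log units higher from compound 3 to compound 4 (beyond the scatter), because the related change gave a number 0.41 log units higher from compound 1 to compound 2 (beyond the scatter). Compound 4 is therefore estimated at 6.65, with a likely range from 6.35 to 7.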

Compound 4, partition coefficient: 6.78
The estimate for compound 4 lay 0.13 log units below the measured number, within the range that was stated.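

In this assay methyl in place of hydrogen on a saturated chain carbon bound to a sulfur gives a number 0.54 log units higher from compound 3 to compound 4 (beyond the scatter) while the related change on a saturated chain carbon bound to three saturated chain carbons gives a number 0.41 log units higher from compound 1 to compound 2 (beyond the scatter) so the two steps run the same way and each lies beyond the scatter. This shows that the direction of the change held on these two cores at these two places, but it rests on a single pair per core. It does not show that the step would carry over at one identical place, and with both core and place differing between the pairs, their contributions cannot be separated; nothing available bears on why either step has the size it has.

The compounds shown leave open how the series would read with a longer chain on the sulfur, such as propyl in place of ethyl, or with an amine or a carboxylic acid on the saturated chain. Also open, on these data alone, is how far the two steps would stay alike at a third place on either core.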